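The source may hold more compounds than are shown below. What is called first, only, known or untested is meant among the compounds shown, and "the series" means these compounds.

Compound 1 `COc1cc(-c2cc(C(=O)O)c3ccccc3n2)ccc1OCC(=O)Nc1ccccc1C` is the reference point of this small set. Within the data shown here, in an ADME assay on HaCaT cells (Homo sapiens) for inhibition (a lower number here means a stronger inhibitor, a higher number a weaker inhibitor), compound 1 gives 230000 nM, and it stands as the only plain number among the three values shown. Compound 2 `COc1cc(-c2cc(C(=O)O)c3ccccc3n2)ccc1OCC(=O)NCc1cccnc1` returns a limit of > 300000 nM in this assay. Compound 3 `COc1cc(-c2cc(C(=O)O)c3ccccc3n2)ccc1OCC(=O)NCc1cccs1` likewise returns a limit of > 300000 nM in this assay. Most of the set therefore sits at the limit of > 300000 nM in this assay, at which 2 of the 3 values shown sit.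

The step under study leads to compound 4 `CCCCCCNC(=O)COc1ccc(-c2cc(C(=O)O)c3ccccc3n2)cc1OC`, which differs from compound 1 by hexyl in place of 2-methylphenyl on an amide-type nitrogen. Among the measured compounds shown here, two measured steps bear on it, both replacing the same 2-methylphenyl on the amide-type nitrogen: an at least 1.3-fold higher number from compound 1 to compound 2 (0.11 log units; that floor lies within the scatter) and an at least 1.3-fold higher number from compound 1 to compound 3 (0.11 log units; that floor lies within the scatter). Neither floor lies beyond the scatter, and the step that the two limits leave unreadable from compound 2 to compound 3 adds no further reading. For the measured compounds named here, exchanging the ring for a chain is a change of a different kind from those two, yet the only comparisons at hand show no movement that the scatter would not cover. The step is thus expected to be a 1.3-fold higher number from compound 1 to compound 4 (0.12 log units; within the scatter). For compound 4 the expected value in this assay is 300000 nM, within a range from 150000 nM to 600000 nM, with a fair chance that only a limit is reported.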

Compound 4, half-maximal inhibitory concentration: > 300000 nM
Compound 4: a limit, no number (the forecaster's own chance of this, stated with the estimate: 55%); the middle value lies on the limit itself.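

Replacing 2-methylphenyl on the amide-type nitrogen with hexyl, a chain with no ring, gives an at least 1.3-fold higher number from compound 1 to compound 4 (0.11 log units; that floor lies within the scatter) in this assay. The earlier steps shown here at this position had only placed other ring-bearing groups there, so this result extends the same reading to an open chain, and this floor too gives no readable difference in size. The steps from compound 2 to compound 4 and from compound 3 to compound 4 cannot be read, and the set gathers further at a single limit: the limit of > 300000 nM in this assay, at which 3 of the 4 values shown sit.

The compounds shown leave open whether any group on this nitrogen can bring the number in this assay clearly lower than for compound 1, which gives 230000 nM. They also leave open how a much shorter chain such as methyl, or a hexyl chain ending in an amine or a carboxylic acid, would read here, and how far the compounds that return limits actually lie from one another.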